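This account rests on a few compounds, and the source may have more. Where it says the series, first, only, none or still open, it means among the compounds named here.

Measured so far in an ADME assay on 2209-23 cells (Homo sapiens) for cytotoxicity, read by WST assay; a lower number here means that less compound is tolerated, a higher number that more compound is tolerated:

compound 1 `CS(=O)(=O)Nc1ccc2c(c1)S(=O)(=O)C=C(c1c(O)c3cc(F)ccc3n(Cc3ccc(F)cc3)c1=O)N2`: > 50000 nM, a limit of the assay.
compound 2 `CS(=O)(=O)Nc1ccc2c(c1)S(=O)(=O)C=C(c1c(O)c3cc(Cl)ccc3n(Cc3ccc(F)cc3)c1=O)N2`: > 50000 nM, a limit of the assay.
compound 3 `CS(=O)(=O)Nc1ccc2c(c1)S(=O)(=O)C=C(c1c(O)c3ccc(F)cc3n(Cc3ccc(F)cc3)c1=O)N2`: > 50000 nM, a limit of the assay.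

Compound 4 `CS(=O)(=O)Nc1ccc2c(c1)S(=O)(=O)C=C(c1c(O)c3ccc(Cl)cc3n(Cc3ccc(F)cc3)c1=O)N2` is not yet measured in this assay. The change from compound 3 to compound 4 is chloro in place of fluoro on an aromatic carbon. The same change is made from compound 1 to compound 2, (chloro in place of fluoro on an aromatic carbon), and the step it gave there is a step that the two limits leave unreadable from compound 1 to compound 2. Three of the three measured values sit at the limit of > 50000 nM in this assay, at which 3 of the 3 values shown sit, so the size of that step is not readable. The difference between the core of compound 1 and the core of compound 3 is not broken down here.

For compound 4, with the same change at the same place, the step that the limit leaves unreadable from compound 3 to compound 4 is expected to be flat, resting on compound 3 sitting at a limit in this assay with > 50000 nM. Compound 4 is thus expected to give about 60000 nM, estimated between 30000 nM and 150000 nM, most likely again reported as a limit.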

Compound 4, half-maximal cytotoxic concentration: > 50000 nM
Compound 4 was reported as a limit (the forecaster's own chance of this, stated with the estimate: 85%); the middle value lies beyond the limit too.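

In this assay, no step can be read between compound 3 and compound 4, as both are reported as a limit: the limit of > 50000 nM in this assay, at which 4 of the 4 values shown sit.

The compounds shown leave open whether chloro and fluoro differ at all in half-maximal cytotoxic concentration, and where any of these compounds would give a measurable value.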